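Replacing the N-alkenyl chain with a chloroaryl group

The source may report more compounds than this note shows. Statements on the series, on what has been measured and on what is new or still open speak of the compounds shown alone.

Compound 1: `C/C=C/Cn1cc(/C=C/C(=O)CC(=O)C(=O)OCC)c2ccccc21` — > 40 uM
Compound 2: `C=C(C)Cn1cc(/C=C/C(=O)CC(=O)C(=O)OCC)c2ccccc21` — > 40 uM

Compound 1 has the structure `C/C=C/Cn1cc(/C=C/C(=O)CC(=O)C(=O)OCC)c2ccccc21` and in an assay on isolated protein for inhibition of DNA nucleotidylexotransferase (Homo sapiens), read by scintillation counting, with a stated time of 10 min (on this read-out higher numbers stand for weaker inhibition and lower numbers for stronger inhibition), compound 1 gives only a limit, > 40 uM. Compound 2, `C=C(C)Cn1cc(/C=C/C(=O)CC(=O)C(=O)OCC)c2ccccc21`, likewise gives only a limit in this assay, > 40 uM. The single step between them, a step that the two limits leave unreadable from compound 1 to compound 2, thus cannot be read; both values sit at the limit of > 40 uM in this assay, at which 2 of the 2 values shown sit, so compound 2 stands at the limit and nowhere else on the numbers shown.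

Compound 3 is `CCOC(=O)C(=O)CC(=O)/C=C/c1cn(-c2ccc(Cl)cc2)c2ccccc12`. It differs from compound 2 by 4-chlorophenyl in place of 2-methylprop-2-en-1-yl on an aromatic nitrogen. For the measured compounds named here, no measured step touches the group on the aromatic nitrogen in a readable way, since the step from compound 1 to compound 2 gives no size, and nothing in the data links an aryl group at that position to a change in this assay. The expectation for compound 3 is therefore no step beyond the scatter, which is the step of a number no higher from compound 2 to compound 3 (the limit leaves the size open). Compound 3 is estimated at 40 uM in this assay, within the range 10 uM to 120 uM, with a fair chance that again only a limit is reported.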

Compound 3, concentration for 50% inhibition: > 40 uM
Compound 3: only a limit was reported; the forecaster's own chance of this, stated with the estimate: 60%; the middle value sits exactly at the limit.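

In this assay compound 3 gives only a limit, > 40 uM. The steps to compound 3 from compound 1 and compound 2 therefore cannot be read: the limit of > 40 uM in this assay, at which 3 of the 3 values shown sit.

The compounds shown leave open whether any group on the aromatic nitrogen gives a measurable value in this assay, and how far compound 1, compound 2 and compound 3 lie apart.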